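Fluorophenyl for nitrophenyl on the decyl-triazole chalcone

This account rests on a few compounds, and the source may have more. Where it says the series, first, only, none or still open, it means among the compounds named here.

Compound 2 `O=C(CN1CCN(c2ccc([N+](=O)[O-])cc2)CC1)Nc1ccc(C(=O)/C=C/c2cn(Cc3ccc(Br)cc3)nn2)cc1` gives 26500 nM in a functional assay on SK-N-SH cells (Homo sapiens) for inhibition, read by MTT assay; a lower number here means a stronger inhibitor, a higher number a weaker inhibitor. Compound 1 `O=C(CN1CCN(c2ccccc2F)CC1)Nc1ccc(C(=O)/C=C/c2cn(Cc3ccc(Br)cc3)nn2)cc1` gives 12800 nM; the change 2-fluorophenyl in place of 4-nitrophenyl on an amine nitrogen in a ring made the step of a 2.1-fold lower number from compound 2 to compound 1 (0.32 log units; beyond the scatter). Compound 3 `CCCCCCCCCCn1cc(/C=C/C(=O)c2ccc(NC(=O)CN3CCN(c4ccc([N+](=O)[O-])cc4)CC3)cc2)nn1` gives 40900 nM; it differs from compound 2 by nonyl in place of 4-bromophenyl on a saturated chain carbon bound to an aromatic nitrogen, a step of a 1.5-fold higher number from compound 2 to compound 3 (0.19 log units; within the scatter). Compound 4 `CCCCCCCCCCn1cc(/C=C/C(=O)c2ccc(NC(=O)CN3CCN(c4ccccc4F)CC3)cc2)nn1` is not yet measured. It differs from compound 3 by 2-fluorophenyl in place of 4-nitrophenyl on an amine nitrogen in a ring, the same change as from compound 2 to compound 1, at a place described in the same words. Going by the values given here, the step from compound 3 to compound 4 is expected to be a 2.0-fold lower number from compound 3 to compound 4 (0.31 log units; beyond the scatter), resting on the single earlier instance a 2.1-fold lower number from compound 2 to compound 1 (0.32 log units; beyond the scatter) and on the core difference a 1.5-fold higher number from compound 2 to compound 3 (0.19 log units; within the scatter), which stays within the scatter. Compound 4 is therefore estimated at 20000 nM, with a range from 9000 nM to 45000 nM.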

Compound 4, half-maximal inhibitory concentration: 34400 nM
The estimate for compound 4 lay 1.7-fold (0.24 log units) below the measured number, within the range that was stated.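

In this assay, 2-fluorophenyl in place of 4-nitrophenyl gives a 1.2-fold lower number from compound 3 to compound 4 (0.08 log units; within the scatter), and the two cores do not separate on this change: the same change on two cores in this assay, a 2.1-fold lower number (0.32 log units; beyond the scatter) from compound 2 to compound 1 and a 1.2-fold lower number (0.08 log units; within the scatter) from compound 3 to compound 4, 1.7-fold (0.24 log units) apart, within the scatter of two such steps. Nonyl in place of 4-bromophenyl gives a 2.7-fold higher number from compound 1 to compound 4 (0.43 log units; beyond the scatter), and this change likewise does not separate the two cores: the same change on two cores in this assay, a 1.5-fold higher number (0.19 log units; within the scatter) from compound 2 to compound 3 and a 2.7-fold higher number (0.43 log units; beyond the scatter) from compound 1 to compound 4, 1.7-fold (0.24 log units) apart, within the scatter of two such steps. This shows agreement across a single pair of cores, but it does not fix the size of either change or show that either carries to any other core. Still open, from the compounds shown here alone, is whether an unsubstituted phenyl or an acetyl group on the amine nitrogen in the ring would follow the same step. The same applies to a shorter chain or a terminal carboxylic acid in place of the nonyl end.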